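Trimming a Sulfonamide Arm Down to a Hydroxymethyl

The source may hold more compounds than are shown below. What is called first, only, known or untested is meant among the compounds shown, and "the series" means these compounds.

Compound 1 `O=C1O/C(=C\Cn2cc(-c3ccc(Br)cc3)nn2)C(OCc2ccccc2)=C1OCc1ccccc1` gives in a functional assay on HCT-116 cells (Homo sapiens) for antiproliferative activity, read by MTT assay, with a stated time of 72 h (on this read-out lower numbers stand for stronger inhibition and higher numbers for weaker inhibition), only a limit, > 100000 nM. Within the data shown here, compound 2 `O=C1O[C@H]([C@@H](O)Cn2cc(CNS(=O)(=O)c3ccc(F)cc3)nn2)C(OCc2ccccc2)=C1OCc1ccccc1` is the one member of the pair with a number in this assay, and compound 2 gives 22900 nM, so it stands as the only measured value here. Compound 3 `O=C1O[C@H]([C@@H](O)Cn2cc(CCO)nn2)C(OCc2ccccc2)=C1OCc1ccccc1` is reached from compound 2 by a single change: hydroxymethyl in place of ((4-fluorophenyl)sulfonyl)amino on a saturated chain carbon bound to an aromatic carbon. Among the measured compounds shown here, no measured step between compounds exists to guide this move, so the expectation rests on the size of the change alone. For compound 3 the expected step is a 2.4-fold higher number from compound 2 to compound 3 (0.38 log units; beyond the scatter), toward weaker inhibition. Compound 3 is estimated at 55000 nM, within a range from 15000 nM to 200000 nM.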

Compound 3, half-maximal inhibitory concentration: 72700 nM
Compound 3: middle estimate off by 1.3-fold (0.12 log units), on the low side; measured number inside the range.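

Swapping the ((4-fluorophenyl)sulfonyl)amino group for hydroxymethyl gives a 3.2-fold higher number from compound 2 to compound 3 (0.50 log units; beyond the scatter) in this assay and so moves toward weaker inhibition. This only measured step at this position shows that compound 3 keeps a measurable value without the aromatic ring of that group, though its number is higher. Compound 1 reads only as a limit, not a number: the limit of > 100000 nM in this assay, at which 1 of the 3 values shown sits.

This single step cannot separate the parts of the departing group from one another. On these data alone, how an amine, a carboxylic acid or a longer chain would read at this place remains open.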